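A few compounds are considered here, and "the series" means these few. Any claim that something is new, unique, unknown or untested is made for them only; others in the source may bear on it.

Measured compounds, all read in a functional assay on U2OS cells (Homo sapiens) for inhibition, read by CCK-8 assay, with a stated time of 72 h, tested at 1 uM; a lower number here means less inhibition, a higher number more inhibition at the concentration tested (going by the name of the read-out):

compound 1 `COc1ccccc1N1C(=O)C(C)SC1c1cccc(C(=O)NCCCCc2ccccc2)c1`: compound 1 gives 38%
compound 2 `COc1cccc(OC)c1N1C(=O)CSC1c1cccc(C(=O)NCCCCc2ccccc2)c1`: compound 2 gives 41%
compound 3 `O=C(NCCCCc1ccccc1)c1cccc(C2OCC(=O)N2c2cccc(F)c2)c1`: compound 3 gives 25%

Compound 2 carries the largest of the three numbers in this assay, but its gap to compound 1 lies within the scatter, so the two cannot be told apart; only compound 3 sits beyond the scatter below compound 2. Within the data shown here, no pair of these three differs in a single place, so no single-point step is available from the measured set.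

Compound 4 `CCN1C(=O)CSC1c1cccc(C(=O)NCCCCc2ccccc2)c1` is the next compound in line. Relative to compound 2 it differs in one place: ethyl in place of 2,6-dimethoxyphenyl on an amide-type nitrogen in a ring. A large group leaves and a small chain enters on the amide-type nitrogen in the ring. Nothing measured in this series shows what such a swap does here, so the expectation rests on the change alone. The number for compound 4 is expected to fall, by a step of a number 19 percentage points lower from compound 2 to compound 4 (beyond the scatter), likely beyond the scatter. Compound 4 is therefore estimated at 22%, within a range from 8% to 38%.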

Compound 4, a percentage reported as inhibition, at one concentration (the size of the read-out at that concentration, not a potency): 13%
Compound 4: middle estimate off by 9 percentage points, on the high side; measured number inside the range.
By their numbers in this assay, from the lowest: compound 4; then compound 3; then compounds 1 and 2 (each within the scatter of the next).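

On the amide-type nitrogen in the ring, the series now has its first single-place step in this assay: with ethyl in place of 2,6-dimethoxyphenyl, the read-out moves by a number 28 percentage points lower from compound 2 to compound 4 (beyond the scatter). This position is therefore not indifferent to its substituent, and with the rest of compound 2 unchanged, the larger aryl group goes with the greater inhibition at this concentration, though this rests on a single pair. The data shown give no measured basis for saying which feature of the departing group accounts for the step.

On these data alone, it remains open whether an unsubstituted phenyl on this nitrogen would read closer to compound 2 or to compound 4, which would separate the contribution of the aromatic ring from that of the two methoxy groups. A longer chain such as hexyl would show whether size alone recovers any of the inhibition.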